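This account rests on a few compounds, and the source may have more. Where it says the series, first, only, none or still open, it means among the compounds named here.

Measured so far in a functional assay on MCF7 cells (Homo sapiens) for cytotoxicity, read by CellTiter-Glo, with a stated time of 5 days; a lower number here means a stronger inhibitor, a higher number a weaker inhibitor:
- Compound 1 (`CC/C(=C(/c1ccc(/C=C/C(=O)O)cc1)c1ccc2[nH]c(=O)sc2c1)c1ccccc1`): 158 nM
- Compound 2 (`CC/C(=C(/c1ccc(/C=C/C(=O)O)c(C)c1)c1ccc2[nH]ncc2c1)c1ccccc1`): 14 nM
- Compound 3 (`CC/C(=C(/c1ccc(/C=C/C(=O)O)cc1)c1ccc2[nH]ncc2c1)c1ccccc1C#N`): 12 nM

Compound 3 stands within the scatter of compound 2 and well beyond the scatter from compound 1, whose number is much higher. Compound 4 (`CC/C(=C(/c1ccc(/C=C/C(=O)O)cc1)c1ccc2[nH]ncc2c1)c1ccc(C#N)cc1C`) has 4-cyano-2-methylphenyl in place of 2-cyanophenyl on a double-bonded chain carbon bound to a double-bonded chain carbon and a saturated chain carbon. Among the compounds with values here, no measured pair isolates this change. Compound 2 (14 nM) and compound 3 (12 nM) differ in more than one place yet show near-equal values, so only a small step is expected in this assay toward a somewhat higher number, probably within the scatter. The estimated change is (a 1.5-fold higher number from compound 3 to compound 4 (0.18 log units; within the scatter)). For compound 4 the estimated value is (18 nM), with an expected range (7 nM to 45 nM).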

Compound 4, half-maximal inhibitory concentration: 5 nM
The estimate for compound 4 lay 3.6-fold (0.56 log units) above the measured number, outside the stated range (below it).
By their numbers in this assay, from the lowest: compound 4; then compounds 3 and 2 (each within the scatter of the next); then compound 1.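

In this assay, the group on a double-bonded chain carbon bound to a double-bonded chain carbon and a saturated chain carbon proves able to move the number: 4-cyano-2-methylphenyl in place of 2-cyanophenyl gives a 2.4-fold lower number from compound 3 to compound 4 (0.38 log units; beyond the scatter), a modest step. Within the data shown here, this is the first comparison here between compounds that differ in one place. Nothing measured here explains the step. From the compounds shown here alone, the change alters the nitrile's ring position and adds the methyl together, so their separate shares remain open. Going by these compounds, how an amine or methoxy group on this ring would fare also remains open.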